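The source may report more compounds than this note shows. Statements on the series, on what has been measured and on what is new or still open speak of the compounds shown alone.

Working notes on the series in a physicochemical assay for solubility, in phosphate buffer, measured as kinetic solubility, at pH 7.4; on this read-out higher numbers stand for higher solubility and lower numbers for lower solubility. Compound 3 `Cc1oc(-c2c(Cl)cccc2C(F)(F)F)nc1CN1CCC(C(=O)NCCCN2C[C@H](C)C[C@H](C)C2)CC1` reads 65.1 ug/mL, within the scatter of compound 1 `Cc1ccc(C)c(-c2nc(CN3CCC(C(=O)NCCCN4C[C@H](C)C[C@H](C)C4)CC3)c(C)o2)c1`, which reads 56.1 ug/mL. Compound 2 `Cc1oc(-c2c(Cl)cccc2Cl)nc1CN1CCC(C(=O)NCCCN2C[C@H](C)C[C@H](C)C2)CC1` gives only a limit, > 77 ug/mL.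

Compound 4 `Cc1cccc(F)c1-c1nc(CN2CCC(C(=O)NCCCN3C[C@H](C)C[C@H](C)C3)CC2)c(C)o1` is still unmeasured. It differs from compound 3 by 2-fluoro-6-methylphenyl in place of 2-chloro-6-(trifluoromethyl)phenyl on an aromatic carbon, with 2-fluoro-6-methylphenyl in place of 2-chloro-6-(trifluoromethyl)phenyl on an aromatic carbon of a five-membered aromatic ring with 1 nitrogen and 1 oxygen.

Among the measured compounds shown here, all the measured steps change this same group. The closest guide is a 1.2-fold higher number from compound 1 to compound 3 (0.06 log units; within the scatter), which stays within the scatter. The floors of an at least 1.3-fold higher number from compound 1 to compound 2 (0.13 log units; that floor lies within the scatter) and an at least 1.1-fold lower number from compound 2 to compound 3 (0.07 log units; that floor lies within the scatter) also lie within the scatter, though they bound those steps from one side only.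

On these steps, no change beyond the scatter is expected in this assay, and no direction can be favoured. The expected step is a 1.1-fold lower number from compound 3 to compound 4 (0.02 log units; within the scatter). For compound 4 the estimated value is 62 ug/mL, with an expected range of 40 ug/mL to 85 ug/mL.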

Compound 4, solubility: > 72 ug/mL
Compound 4 gave a limit, no number (the forecaster's own chance of this, stated with the estimate: 30%); middle value at least 1.1-fold (0.06 log units) away from the limit.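

In this assay compound 4 gives a limit and not a number: the limit of > 72 ug/mL in this assay, at which 1 of the 4 values shown sits.

With 2-fluoro-6-methylphenyl on this aromatic carbon, the floors of an at least 1.1-fold higher number from compound 3 to compound 4 (0.04 log units; that floor lies within the scatter) and an at least 1.2-fold higher number from compound 1 to compound 4 (0.10 log units; that floor lies within the scatter) both point upward, but each bounds its step from one side only and neither passes the scatter. A phenyl group with no chlorine now also ends in a limit, as the 2,6-dichlorophenyl of compound 2 does, while compound 1 and compound 3 give numbers, and the step between the two limits of compound 2 and compound 4 cannot be read.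

Going by these compounds, how far either of these two compounds really lies from compound 1 and compound 3 stays open. On these data alone, all four compounds carry a substituted phenyl here, so the effect of a phenyl bearing an amine or a carboxylic acid at this position is also open.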